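Aryl variation at the saturated ring carbon: cytotoxicity notes

A few compounds are considered here, and "the series" means these few. Any claim that something is new, unique, unknown or untested is made for them only; others in the source may bear on it.

The series keeps one core and changes only the aryl group on a saturated ring carbon. Compound 1 `COc1cc(N2C(N)=C(C#N)C(c3c(O)ccc4ccccc34)C3=C2CC(C)(C)CC3=O)cc(OC)c1OC` carries 2-hydroxynaphthalen-1-yl there, and in a functional assay on Ehrlich cells (Mus musculus) for cytotoxicity, tested at 100 ug/mL (a lower number here means a weaker effect, a higher number a stronger effect of the compound at the concentration tested), compound 1 gives 90%. Compound 2 `COc1cc(N2C(N)=C(C#N)C(c3ccc(Cl)cc3Cl)C3=C2CC(C)(C)CC3=O)cc(OC)c1OC` carries 2,4-dichlorophenyl, and in this assay compound 2 gives 100%. Compound 3 `COc1ccccc1C1C(C#N)=C(N)N(c2cc(OC)c(OC)c(OC)c2)C2=C1C(=O)CC(C)(C)C2` carries 2-methoxyphenyl, and in this assay compound 3 gives 100%. Compound 2 stands level with compound 3, the two together the highest of the three numbers; its nearest neighbour is compound 3, with no change at the digits printed from compound 2 to compound 3 (within the scatter), and its furthest is compound 1, with a number 10 percentage points higher from compound 1 to compound 2 (within the scatter). The remaining measured step, a number 10 percentage points higher from compound 1 to compound 3 (within the scatter), is likewise within the scatter.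

Compound 4 `COc1cc(N2C(N)=C(C#N)C(c3ccccc3)C3=C2CC(C)(C)CC3=O)cc(OC)c1OC` has not yet been measured in this assay. Against compound 2 it shows (phenyl in place of 2,4-dichlorophenyl on a saturated ring carbon). All three measured steps concern the aryl group on this saturated ring carbon and all lie within the scatter, so for compound 4 the expected step is a number 5 percentage points lower from compound 2 to compound 4 (within the scatter), none beyond the scatter. For compound 4 the estimate in this assay is 95%, with a range from 80% to 100%. This expectation rests on three compounds only; plain phenyl has not been tested in this series.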

Compound 4, a percentage reported as activity, at one concentration (the size of the read-out at that concentration, not a potency): 10%
Compound 4: middle estimate off by 85 percentage points, on the high side, outside the stated range (below it).
By their numbers in this assay, from the lowest: compound 4; then compounds 1, 2 and 3 (each within the scatter of the next).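

The aryl group on this saturated ring carbon is not interchangeable in this assay: taking both chlorines off the 2,4-dichlorophenyl group to leave phenyl gives a number 90 percentage points lower from compound 2 to compound 4 (beyond the scatter) and marks this position as one where a small change can matter. Hydrogen in place of methoxy on an aromatic carbon of the 2-methoxyphenyl group gives a number 90 percentage points lower from compound 3 to compound 4 (beyond the scatter) and phenyl in place of 2-hydroxynaphthalen-1-yl gives a number 80 percentage points lower from compound 1 to compound 4 (beyond the scatter) so that all three earlier aryl groups, which showed no step beyond the scatter among themselves, stand apart from plain phenyl. No measurement at hand bears on what lies behind this drop, and the data give no cause for it.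

Going by these compounds, whether a single chlorine or a single methoxy group on the phenyl ring is enough to restore the read-out stays open, as does how a phenyl ring carrying an amine, a carboxylic acid or a methyl group would behave in this assay at this position. The read-outs come from one concentration, so they give the size of the effect at that concentration and leave the potency of all four compounds open.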